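This account rests on a few compounds, and the source may have more. Where it says the series, first, only, none or still open, it means among the compounds named here.

Measured compounds:
compound 1 `COc1cccc(N2CCN(C(=O)C(C)N3C(=O)CCC3=O)CC2)c1`: 0%
compound 2 `CCC(C(=O)N1CCN(c2ccc(C(F)(F)F)cc2)CC1)N1C(=O)CCC1=O`: 0%
compound 3 `COCC(C(=O)N1CCN(c2cccc(C(F)(F)F)c2)CC1)N1C(=O)CCC1=O`: 100%

In a functional assay on the whole organism (strain Swiss) with Mus musculus as the target, in the maximal electroshock model, with a stated time of 1 h, at a dose of 300 mg/kg by the intraperitoneal route (on this read-out lower numbers stand for a weaker effect and higher numbers for a stronger effect at the one dose given), compound 1 gives 0%, level with compound 2 at the digits shown and together with it the lowest of the three numbers, while compound 3 lies far higher, well beyond the scatter. Compound 4 `CC(C(=O)N1CCN(c2ccc(Cl)cc2)CC1)N1C(=O)CCC1=O` carries 4-chlorophenyl in place of 3-methoxyphenyl on an amine nitrogen in a ring. For the measured compounds named here, no pair of measured compounds isolates this change: compound 2 and compound 3 each differ from compound 1 in more than one place, so the effect of the aryl swap alone cannot be read from them. Because compound 3 reaches 100% from the same core, an upward step is expected a number 25 percentage points higher from compound 1 to compound 4 (beyond the scatter), though with wide uncertainty. Compound 4 is estimated at 25%, within a range from 0% to 75%.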

Compound 4, a percentage reported as activity, at one dose (the size of the read-out at that dose, not a potency): 0%
For compound 4 the middle estimate is 25 percentage points above the measured one; measured number inside the range.
By their numbers in this assay, from the lowest: compounds 1, 2 and 4 (each within the scatter of the next); then compound 3.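

In this assay, for the compounds shown here, 4-chlorophenyl in place of 3-methoxyphenyl on the amine nitrogen in the ring gives no change at the digits printed from compound 1 to compound 4 (within the scatter) and thus provides the only single-place comparison at this position. This one swap therefore does not lift the read-out from the level of compound 1. Nothing available offers an explanation for this result.

Going by these compounds, it remains open whether the aryl group, the side chain, or both separate compound 3 from compound 1. On these data alone, how a pyridine ring or a nitrile-bearing phenyl ring would read at this position also remains open.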